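This account rests on a few compounds, and the source may have more. Where it says the series, first, only, none or still open, it means among the compounds named here.

Measured compounds in a toxicity assay on MCF7 cells (Homo sapiens) for cytotoxicity, read by MTT assay; on this read-out higher numbers stand for weaker inhibition of growth and lower numbers for stronger inhibition of growth:

- Compound 1, `C/C(=N\Nc1nc(-c2ccc(Cl)cc2)cs1)c1sc(C)nc1C`: in this assay compound 1 gives > 100 ug/mL, which is a limit of the assay and not a number.
- Compound 2, `C/C(=N\Nc1nc(-c2ccc(C)cc2)cs1)c1sc(C)nc1C`: in this assay compound 2 gives > 100 ug/mL, likewise a limit of the assay.

Compound 2 thus stands at the limit of > 100 ug/mL in this assay, at which 2 of the 2 values shown sit; it cannot be placed more closely than that. Among the compounds with values here, the only step between measured compounds, a step that the two limits leave unreadable from compound 1 to compound 2, is unreadable, as both ends are limits.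

Compound 3, `COc1ccc(-c2csc(N/N=C(\C)c3sc(C)nc3C)n2)cc1`, differs from compound 2 by methoxy in place of methyl on an aromatic carbon. Within the data shown here, no measured step speaks to this change, and the one step that exists gives no size. On this basis no step beyond the scatter is expected in this assay, and the estimated a number no higher from compound 2 to compound 3 (the limit leaves the size open) is about none. Compound 3 is therefore estimated at 100 ug/mL, within 50 ug/mL to 200 ug/mL, with a high chance that the assay again reports only a limit.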

Compound 3, concentration for 50% growth inhibition: > 100 ug/mL
Compound 3: only a limit was reported; the forecaster's own chance of this, stated with the estimate: 75%; the middle value lies on the limit itself.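

No step can be read among compound 1, compound 2 and compound 3, as each result in this assay is a limit of the assay and not a number: the limit of > 100 ug/mL in this assay, at which 3 of the 3 values shown sit. The compounds shown leave open whether chloro, methyl and methoxy differ at all in this assay.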